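Removing a Protecting Group from an Amine on the Core

The source may report more compounds than this note shows. Statements on the series, on what has been measured and on what is new or still open speak of the compounds shown alone.

Of the compounds shown here, three have been measured in a functional assay on cells (Splenocyte, Mus musculus, strain BALB/c) for inhibition, read by scintillation counting and thymidine incorporation, with stated times of 48 h and 8 h; on this read-out lower numbers stand for stronger inhibition and higher numbers for weaker inhibition. Compound 1 `CCc1ccc(-c2noc(Cc3c[nH]c4ccccc34)n2)cc1` gives 13900 nM. Compound 2 `COc1cc(-c2noc(-c3ccc(N)cc3)n2)cc(OC)c1OC` gives 1700 nM. Compound 3 `COc1cc(-c2noc(C34CCC(NC(=O)OC(C)(C)C)(CC3)CC4)n2)cc(OC)c1OC` gives 3600 nM, the second highest of the three numbers; compound 2 is its nearest neighbour at a lower number and compound 1 its furthest at a higher one, and both gaps lie beyond the usual scatter.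

The next compound, compound 4 `COc1cc(-c2noc(C34CCC(N)(CC3)CC4)n2)cc(OC)c1OC`, differs from compound 3 in one place: hydrogen in place of tert-butoxycarbonyl on an amine nitrogen. Within the data shown here, no measured pair so far shows this exact change on this core, so the direction has to be judged loosely. Compound 2, which also carries a free amino group, gives the lowest number of the three, but it is not a single-change neighbour of compound 3, so its value only hints at what a free amine may do here.

The estimated step is a 1.4-fold lower number from compound 3 to compound 4 (0.16 log units; within the scatter), a modest move toward a lower number that may still fall within the scatter. Compound 4 is expected to give about 2500 nM, with a range from 800 nM to 8000 nM.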

Compound 4, half-maximal inhibitory concentration: 4100 nM
The estimate for compound 4 lay 1.6-fold (0.21 log units) below the measured number; measured number inside the range.
By their numbers in this assay, from the lowest: compound 2; then compounds 3 and 4 (each within the scatter of the next); then compound 1.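

Replacing tert-butoxycarbonyl with hydrogen on the amine nitrogen gives a 1.1-fold higher number from compound 3 to compound 4 (0.06 log units; within the scatter) in this assay, so the two compounds cannot be told apart in this assay. Among these compounds, this is the first direct look at this position: on the shared core, the nitrogen on the saturated ring carbon can carry either the bare hydrogen or a group of 7 heavy atoms with no change beyond the usual scatter. No measurement here bears on why the two compounds read alike.

These two compounds give only the extremes of small and bulky on this nitrogen, so an acetyl or methyl group there could still read differently. A carboxylic acid in place of the amine also remains an open question on this core.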